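Sulfonyl aryl swap on the piperidinyl-piperidine sulfonamides

The compounds below may be only part of what the source reports. "The series", "measured", "known", "first", "only" and "open" are said of these compounds alone.

Compound 1 `Cc1ccc(S(=O)(=O)N2CCC(N3CCC(C)CC3)CC2)cc1C` gives 24 nM in a functional assay on DLD-1 cells (Homo sapiens) for antiproliferative activity, read by CellTiter-Glo, with a stated time of 72 h; a lower number here means a stronger inhibitor, a higher number a weaker inhibitor. Compound 2 `CC1CCN(C2CCN(S(=O)(=O)c3cn(C)cn3)CC2)CC1` returns only a limit in this assay, namely > 5000 nM. Where compound 2 stands is therefore bounded by the limit of > 5000 nM in this assay, at which 1 of the 2 values shown sits, and is not fixed as a number. For the measured compounds named here, the step of an at least 200-fold higher number from compound 1 to compound 2 (2.31 log units; beyond the scatter) is the single measured step in the set, and it is large. Compound 3 `CC1CCN(C2CCN(S(=O)(=O)c3ccc(Cl)c(Cl)c3)CC2)CC1` differs from compound 2 by 3,4-dichlorophenyl in place of 1-methyl-1H-imidazol-4-yl on a sulfonyl sulfur. Going by the values given here, this change runs the measured step in reverse: the five-membered aromatic ring with two hetero atoms leaves and a six-membered aromatic ring of carbon only, carrying two substituents, enters on the same sulfonyl sulfur, as in compound 1, so the one measured step bears directly on it and points to a large drop in the number in this assay. Among the compounds with values here, the chlorine-for-methyl difference between compound 3 and compound 1 has no measured counterpart in the set. The expected step of an at least 160-fold lower number from compound 2 to compound 3 (2.22 log units; beyond the scatter) is a large fall for compound 3. Compound 3 is estimated at 30 nM, with a range from 8 nM to 150 nM.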

Compound 3, half-maximal inhibitory concentration: 2.9 nM
Compound 3: the middle estimate sits 10-fold (1.01 log units) above what was measured, and the stated range ends above it.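

For the compounds shown here, the sulfonyl sulfur tolerates a clear difference even between two six-membered aromatic rings of carbon only: 3,4-dichlorophenyl in place of 3,4-dimethylphenyl gives an 8.3-fold lower number from compound 1 to compound 3 (0.92 log units; beyond the scatter) in this assay, so the earlier contrast with the imidazole was not the only change at this place that moves the number. Against 1-methyl-1H-imidazol-4-yl, the same 3,4-dichlorophenyl group gives an at least 1700-fold lower number from compound 2 to compound 3 (3.23 log units; beyond the scatter), which widens the gap at this place beyond what compound 1 alone had shown. The reading for compound 2 remains a limit and not a number: the limit of > 5000 nM in this assay, at which 1 of the 3 values shown sits.

The compounds shown do not separate the contribution of each chlorine, and they leave open whether a single chlorine, a trifluoromethyl group or a methoxy group on the phenyl ring would hold the number near that of compound 3. The shared core is also constant throughout, so the effect of a pyridine ring on the sulfonyl sulfur, or of an amide or a carboxylic acid elsewhere on the core, stays unresolved.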